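A few compounds are considered here, and "the series" means these few. Any claim that something is new, unique, unknown or untested is made for them only; others in the source may bear on it.

Working notes on the series. Among the compounds with values here, in a functional assay on T47D cells (Homo sapiens) for inhibition, read by CCK-8 assay, with a stated time of 72 h, tested at 10 uM (on this read-out higher numbers stand for more inhibition of growth at the one concentration tested and lower numbers for less inhibition of growth), compound 1 `CN(C)C(=O)c1cc2cnc(Nc3ccc(NC(=O)C4(C(=O)Nc5cccc(O)c5)CC4)cc3)nc2n1C1CCCC1` gives 83.7% and compound 2 `CN(C)C(=O)c1cc2cnc(Nc3ccc(NC(=O)C4(C(=O)Nc5ccccc5F)CC4)cc3)nc2n1C1CCCC1` gives 97.8% as the higher of the two numbers so far. Within the data shown here, the one measured step of a number 14.1 percentage points higher from compound 1 to compound 2 (beyond the scatter) exchanges 3-hydroxyphenyl for 2-fluorophenyl on an amide-type nitrogen. Next is compound 3 `CN(C)C(=O)c1cc2cnc(Nc3ccc(NC(=O)C4(C(=O)Nc5cccc(C(F)(F)F)c5)CC4)cc3)nc2n1C1CCCC1` with 3-(trifluoromethyl)phenyl in place of 2-fluorophenyl on an amide-type nitrogen. Among the measured compounds shown here, that modest step is the only one bearing on the change, as it falls at the same place, and no measured compound carries the entering group. Compound 2 at 97.8% leaves little room upward on this read-out. A small fall in this assay is expected, possibly none beyond the scatter, and the estimated step is a number 7.8 percentage points lower from compound 2 to compound 3 (within the scatter) on present evidence. For compound 3 the expected value is 90% with an estimated range from 74% to 102% in this read-out.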

Compound 3, percent growth inhibition at one concentration: 92.7%
Beside the measured number, compound 3's estimate is 2.7 percentage points below it; low and high end bracket the measured number.
By their numbers in this assay, from the lowest: compounds 1, 3 and 2 (each within the scatter of the next, the first and the last beyond it).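

On the amide-type nitrogen, this assay does not separate 3-(trifluoromethyl)phenyl from 2-fluorophenyl: the exchange gives a number 5.1 percentage points lower from compound 2 to compound 3 (within the scatter) and so tolerates a group of 10 heavy atoms in place of one of 7 without a change beyond the scatter. Trifluoromethyl in place of hydroxy on an aromatic carbon gives a number 9 percentage points higher from compound 1 to compound 3 (within the scatter) and is likewise unresolved, so compound 3 cannot be told apart from either compound 1 or compound 2, although those two differ beyond the scatter. No available evidence bears on what lies behind these numbers.

The groups shown at this place are all substituted phenyl rings, so an amine or a carboxylic acid on the ring, or cyclohexyl in place of the phenyl ring, remains open. From the compounds shown here alone, with a single concentration, any finer ranking of compound 2 and compound 3 also remains open.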